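This account rests on a few compounds, and the source may have more. Where it says the series, first, only, none or still open, it means among the compounds named here.

Compound 3 `CCOc1ccc(-c2ncnn2-c2cc(OC)c(OC)c(OC)c2)cc1Cl` gives 10 nM in a functional assay on A549 cells (Homo sapiens) for antiproliferative activity, read by MTT assay, with a stated time of 72 h (a higher number here means a weaker inhibitor, a lower number a stronger inhibitor), the lowest of the two numbers shown; compound 2 `COc1ccc(-c2ncnn2-c2cc(OC)c(OC)c(OC)c2)cc1` gives 520 nM in this assay. Compound 1 `COc1cc(-n2ncnc2-c2ccc(F)cc2)cc(OC)c1OC` returns only a limit, > 10000 nM (the limit of > 10000 nM in this assay, at which 1 of the 3 values shown sits). Going by the values given here, the one measured step, an at least 19-fold lower number from compound 1 to compound 2 (1.28 log units; beyond the scatter), changes a different group on that ring and does not bear directly on the step to compound 4 `CCOc1ccc(-c2ncnn2-c2cc(OC)c(OC)c(OC)c2)cc1`, which is hydrogen in place of chloro on an aromatic carbon. Compound 2 and compound 3 differ in two places, so their gap cannot be assigned to the chloro alone. For compound 4 a step of an 8.0-fold higher number from compound 3 to compound 4 (0.90 log units; beyond the scatter) is expected, weakening. Compound 4 is estimated at 80 nM, within 15 nM to 500 nM.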

Compound 4, half-maximal inhibitory concentration: 100 nM
Compound 4: middle estimate off by 1.3-fold (0.10 log units), on the low side; the measured number falls inside the stated range.
By their numbers in this assay, from the lowest: compound 3; then compound 4; then compound 2. At a limit, above all of these: compound 1.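

In this assay, the chloro ortho to the ethoxy group contributes measurably, since removing it gives a 10-fold higher number from compound 3 to compound 4 (1.00 log units; beyond the scatter). Without chloro, the alkoxy chain also matters: a 5.2-fold lower number from compound 2 to compound 4 (0.72 log units; beyond the scatter). Ethoxy in place of fluoro gives an at least 100-fold lower number from compound 1 to compound 4 (2.00 log units; beyond the scatter), a size that is only a bound, since compound 1 stands at a limit: the limit of > 10000 nM in this assay, at which 1 of the 4 values shown sits.

Open, from the compounds shown here alone, is whether bromo or an amine at the chloro position would match chloro. Also open, going by these compounds, is whether a propoxy chain would extend the trend from methoxy to ethoxy.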